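Acetyl capping of the aromatic amine in the anilide series

The source may hold more compounds than are shown below. What is called first, only, known or untested is meant among the compounds shown, and "the series" means these compounds.

Working notes. Compound 2 `Nc1cccc(-c2csc(NC(=O)CCCCCC(=O)Nc3ccccc3N)n2)c1` carries a free amino group on the aromatic ring and an anilide at the chain end. In an assay on isolated protein for inhibition of protein deacetylase HDAC6 (Homo sapiens), read by fluorescence, with a stated time of 17 h (on this read-out lower numbers stand for stronger inhibition and higher numbers for weaker inhibition), compound 2 gives only a limit, > 30000 nM. Compound 1 `CCOC(=O)Nc1cccc(-c2csc(NC(=O)CCCCCC(=O)Nc3ccccc3N)n2)c1`, with ethoxycarbonyl on that same nitrogen, also returns a limit in this assay, > 30000 nM. Both sit at the limit of > 30000 nM in this assay, at which 2 of the 3 values shown sit, so a step that the two limits leave unreadable from compound 1 to compound 2. Among the measured compounds shown here, compound 3 `Nc1cccc(-c2csc(NC(=O)CCCCCC(=O)NO)n2)c1` is the one compound of the three with a number: in this assay compound 3 gives 3.3 nM, and the step of an at least 9000-fold lower number from compound 2 to compound 3 (3.95 log units; beyond the scatter) shows that the chain end, not the aromatic amine, decides what is seen here.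

Compound 4 `CC(=O)Nc1cccc(-c2csc(NC(=O)CCCCCC(=O)Nc3ccccc3N)n2)c1` is the next variation: acetyl in place of hydrogen on a nitrogen on an aromatic ring. The aromatic nitrogen is capped again, while the chain end of compound 2 is kept unchanged. For the measured compounds named here, the only measured step on this nitrogen, from compound 1 to compound 2, cannot be read because of the limit of > 30000 nM in this assay, at which 2 of the 3 values shown sit. Going by the values given here, the one readable step, from compound 2 to compound 3, concerns the other end and does not bear on this change. Among the compounds with values here, no measured step therefore predicts a move for compound 4 beyond the scatter, and the value is expected to remain at the limit. Compound 4 is estimated at 40000 nM, between 12000 nM and 120000 nM. The step from compound 2 that this estimate means is expected to be a step that the limit leaves unreadable from compound 2 to compound 4.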

Compound 4, half-maximal inhibitory concentration: 11200 nM
For compound 4 the middle estimate is 3.6-fold (0.55 log units) above the measured one; measured number outside the range, below it.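

In this assay compound 4 gives 11200 nM, the only number among the anilides shown, so the aromatic nitrogen does register in this series even with the chain end unchanged. Set against the free amino group, the change gives an at least 2.6-fold lower number from compound 2 to compound 4 (0.42 log units; beyond the scatter), and methyl in place of ethoxy on the carbonyl carbon gives an at least 2.6-fold lower number from compound 1 to compound 4 (0.42 log units; beyond the scatter). Capping this nitrogen is therefore not enough by itself to give a number: compound 1, capped with ethoxycarbonyl, returns only a limit, and the group on the carbonyl carbon makes a difference here.

From the compounds shown here alone, the remaining step on this nitrogen cannot be read, and the true size of both new steps stays open, because the values they start from are limits: the limit of > 30000 nM in this assay, at which 2 of the 4 values shown sit. Open too is whether a propionyl or benzoyl group on this nitrogen would carry the change further, and whether acetyl has any readable effect when the chain end bears hydroxy in place of 2-aminophenyl on the amide-type nitrogen.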